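Dimethylpyrimidinyl in place of pyrimidinyl on the sulfonamide nitrogen

The compounds below may be only part of what the source reports. "The series", "measured", "known", "first", "only" and "open" are said of these compounds alone.

Measured so far:
compound 1 `O=C1/C(=C/c2coc3ccccc3c2=O)N=C(c2ccc(Cl)cc2)N1c1ccc(S(=O)(=O)Nc2ncccn2)cc1` gives > 100000 nM in a functional assay on MCF7 cells (Homo sapiens) for cytotoxicity, read by sulforhodamine B assay, with a stated time of 72 h; a higher number here means a weaker inhibitor, a lower number a stronger inhibitor
compound 2 `Cc1cc(C)nc(NS(=O)(=O)c2ccc(NCc3coc4ccccc4c3=O)cc2)n1` gives 93600 nM in this assay
compound 3 `O=c1c(CNc2ccc(S(=O)(=O)Nc3ncccn3)cc2)coc2ccccc12` gives > 100000 nM in this assay

Compound 1 stands at a limit of the assay, so its value is not a number. The same holds for compound 3, which also sits at a limit. Two of the three values rest at that limit (the limit of > 100000 nM in this assay, at which 2 of the 3 values shown sit). For the measured compounds named here, compound 2 returns a number, and the one measured step that bears on the present question, an at least 1.0-fold higher number from compound 2 to compound 3 (0.02 log units; that floor lies within the scatter), lies within the scatter.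

Compound 4 `Cc1cc(C)nc(NS(=O)(=O)c2ccc(N3C(=O)/C(=C/c4coc5ccccc5c4=O)N=C3c3ccc(Cl)cc3)cc2)n1` arises from compound 1 by 4,6-dimethylpyrimidin-2-yl in place of pyrimidin-2-yl on a sulfonamide nitrogen. Going by the values given here, this is the reverse of the only measured step on the same position, which showed no movement beyond the scatter. The expectation for this assay is therefore no step beyond the scatter, in either direction, with compound 4 most likely remaining at or near the limit.

Compound 4 is estimated at 110000 nM, with a range of 55000 nM to 300000 nM.

The estimate implies an expected step that the limit leaves unreadable from compound 1 to compound 4.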

Compound 4, half-maximal inhibitory concentration: 93900 nM
Estimate against measurement, compound 4: 1.2-fold (0.07 log units) above, and the stated range covers the measured number.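

The change now has a second core behind it: in this assay, 4,6-dimethylpyrimidin-2-yl in place of pyrimidin-2-yl on a sulfonamide nitrogen gives an at least 1.0-fold lower number from compound 1 to compound 4 (0.02 log units; that floor lies within the scatter). On both cores the 4,6-dimethylpyrimidin-2-yl compound returns a number and the pyrimidin-2-yl compound stands at a limit, so the two readings agree as far as they can be read: the same change on two cores in this assay, an at least 1.0-fold higher number (0.02 log units; that floor lies within the scatter) from compound 2 to compound 3 and an at least 1.0-fold higher number (0.02 log units; that floor lies within the scatter) from compound 4 to compound 1; the limit leaves it open whether they differ. Only floors are available for the size of this change, and part of the series rests at the limit: the limit of > 100000 nM in this assay, at which 2 of the 4 values shown sit.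

Going by these compounds, whether 4,6-dimethylpyrimidin-2-yl brings any real difference on either core stays open while the pyrimidin-2-yl partners have no number. Also open, on these data alone, is how this assay responds to a different kind of group on the sulfonamide nitrogen, such as an acetyl group or a thiazol-2-yl ring.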